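A few compounds are considered here, and "the series" means these few. Any claim that something is new, unique, unknown or untested is made for them only; others in the source may bear on it.

Permeability across the series is followed in an ADME assay on Caco-2 cells (Homo sapiens) for permeability, in the apical to basolateral direction; a lower number here means that the compound crosses the layer more slowly, a higher number that the compound crosses the layer faster. Compound 1 `CC(C)COc1ncc(-c2cn(C)c3cc(C(=O)NS(C)(=O)=O)ccc23)cc1Cl` reaches only the limit of this assay, < 15 nm/s. Compound 2 `CC(C)COc1ncc(-c2cn(C)c3cc(C(=O)NS(C)(=O)=O)c(F)cc23)cc1Cl` carries a fluoro on the ring bearing the (methylsulfonyl)carbamoyl group and gives 20 nm/s in this assay. The change between the two is hydrogen in place of fluoro on an aromatic carbon; it brought an at least 1.3-fold lower number from compound 2 to compound 1 (0.12 log units; that floor lies within the scatter), and the size of that step rests on (the limit of < 15 nm/s in this assay, at which 1 of the 3 values shown sits), so only its floor is known. Compound 3 `Cn1cc(-c2ccc(C(F)(F)F)cc2)c2cc(F)c(C(=O)NS(C)(=O)=O)cc21` belongs to a second core; the difference between the two cores is not broken down here. In this assay compound 3 gives 20 nm/s, level with compound 2 at the digits shown. Compound 4 `Cn1cc(-c2ccc(C(F)(F)F)cc2)c2ccc(C(=O)NS(C)(=O)=O)cc21` is not yet measured; it differs from compound 3 by hydrogen in place of fluoro on an aromatic carbon, the same change as from compound 2 to compound 1, at a place described in the same words. This is the second time the change appears among the compounds shown. For compound 4 the expected step is a 1.4-fold lower number from compound 3 to compound 4 (0.15 log units; within the scatter), resting on the measured step from compound 2 to compound 1, an at least 1.3-fold lower number from compound 2 to compound 1 (0.12 log units; that floor lies within the scatter), whose floor is set by the limit. Compound 4 is accordingly estimated at 14 nm/s, with a range from 7 nm/s to 28 nm/s, and with a real chance that it too reaches only the limit of this assay.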

Compound 4, apparent permeability: < 15 nm/s
Compound 4: a limit, no number; the forecaster's own chance of this, stated with the estimate: 50%; the middle value lies beyond the limit too.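

In this assay, hydrogen in place of fluoro on an aromatic carbon, ortho to the (methylsulfonyl)carbamoyl group, gives an at least 1.3-fold lower number from compound 3 to compound 4 (0.12 log units; that floor lies within the scatter). Both compounds that carry the hydrogen, compound 1 and compound 4, end at a limit of the assay and not at a number, so the change points the same way on both cores, but only as far as a floor within the scatter can show it, and the two steps can be set side by side no further than this: the same change on two cores in this assay, an at least 1.3-fold lower number (0.12 log units; that floor lies within the scatter) from compound 2 to compound 1 and an at least 1.3-fold lower number (0.12 log units; that floor lies within the scatter) from compound 3 to compound 4; the limit leaves it open whether they differ. The result therefore does not show that the change has the same size on the two cores, nor that its size depends on the core, and any real size remains hidden behind the floor of the assay: the limit of < 15 nm/s in this assay, at which 2 of the 4 values shown sit.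

Still open, from the compounds shown here alone, is how a chloro or a methoxy group on that same aromatic carbon would read in this assay, and whether the step would keep its direction on a core whose values stand clear of the limit. Also open, going by these compounds, is what a carboxylic acid in place of the (methylsulfonyl)carbamoyl group would give on either core, with or without the fluoro.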